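Side-group replacement from compound 1 to compound 4

The source may hold more compounds than are shown below. What is called first, only, known or untested is meant among the compounds shown, and "the series" means these compounds.

Going by the values given here, in a functional assay on the whole organism (stomach) for inhibition, with Rattus norvegicus as the target (on this read-out higher numbers stand for an effect only at larger amounts of compound and lower numbers for an effect already at smaller amounts), compound 1 `O=C(O)CCC/C=C1\CC2C[C@@H](O)[C@H](/C=C/[C@@H](O)C3COc4ccccc4O3)C2C1` gives 0.0045 mg/kg as the lowest of the three numbers so far. Compound 3 `CC1([C@H](O)/C=C/[C@@H]2C3C/C(=C/CCCC(=O)O)CC3C[C@H]2O)COc2ccccc2O1` lies nearest with 0.0142 mg/kg and compound 2 `Cc1ccc2c(c1)OCC([C@H](O)/C=C/[C@@H]1C3C/C(=C/CCCC(=O)O)CC3C[C@H]1O)O2` lies furthest with 0.11 mg/kg and both gaps are beyond the scatter.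

Compound 4 `CC1([C@H](O)/C=C/[C@@H]2C3C/C(=C/CCCC(=O)O)CC3C[C@H]2O)Cc2ccccc2C1` has not been measured. Its change from compound 1 is 2-methyl-2,3-dihydro-1H-inden-2-yl in place of 2,3-dihydro-1,4-benzodioxin-2-yl on a saturated chain carbon bound to a double-bonded chain carbon and an oxygen on a saturated carbon with 2-methyl-2,3-dihydro-1H-inden-2-yl in place of 2,3-dihydro-1,4-benzodioxin-2-yl on a saturated chain carbon bound to a double-bonded chain carbon and an oxygen on a saturated carbon.

The closest guide is a 3.2-fold higher number from compound 1 to compound 3 (0.50 log units; beyond the scatter) for a methyl on a saturated ring carbon, a feature compound 4 also carries. The larger 24-fold higher number from compound 1 to compound 2 (1.39 log units; beyond the scatter) came with a methyl on an aromatic carbon, which compound 4 lacks, so it shows only how far one small change can move this series. Among the compounds with values here, no measured compound shows the step for losing the ring oxygens or for the five-membered ring, so the expectation stays wide.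

The step expected is a 6.7-fold higher number from compound 1 to compound 4 (0.82 log units; beyond the scatter) in this assay and it points to a higher number. For compound 4 the expected value is 0.03 mg/kg within an estimated range of 0.006 mg/kg to 0.15 mg/kg for now.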

Compound 4, dose for half-maximal effect: 0.0452 mg/kg
Beside the measured number, compound 4's estimate is 1.5-fold (0.18 log units) below it; the measured number falls inside the stated range.
By their numbers in this assay, from the lowest: compound 1; then compound 3; then compound 4; then compound 2.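

The step of a 10-fold higher number from compound 1 to compound 4 (1.00 log units; beyond the scatter) shows that at this saturated chain carbon, a group of the same heavy-atom size made of carbon only, with a five-membered non-aromatic ring in place of the six-membered ring with its hetero atoms, gives a clearly higher number than the 2,3-dihydro-1,4-benzodioxin-2-yl of compound 1, yet compound 2 still stands higher in this assay. Compound 3 gives 0.0142 mg/kg with the methyl on the oxygen-containing ring, and compound 4 gives 0.0452 mg/kg with the carbon-only ring, so compound 1 remains the lowest of the four and no replacement shown improves on it in this assay. Nothing available explains why the number rises with this replacement.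

The step combines the loss of the ring oxygens, the smaller ring and the added methyl, and the compounds shown do not separate these parts. A plain 2,3-dihydro-1H-inden-2-yl without the methyl, or a 2-methyl group carrying a single ring oxygen or an amine in the ring, would be needed to tell how much of the step belongs to each part.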